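Removing a chloro from compound 2: an expectation

A few compounds are considered here, and "the series" means these few. Any claim that something is new, unique, unknown or untested is made for them only; others in the source may bear on it.

In a functional assay on MDA-MB-231 cells (Homo sapiens) for cytotoxicity, read by sulforhodamine B assay, with a stated time of 72 h (on this read-out higher numbers stand for weaker inhibition of growth and lower numbers for stronger inhibition of growth), compound 2 `O=C(Nc1ccccc1O)C1CCc2ccccc2N1C(=O)c1ccccc1Cl` gives 47400 nM, the second highest of three numbers. Compound 1 `CC(=O)N1c2ccccc2CCC1C(=O)Nc1ccccc1O` gives 89600 nM, and the step of a 1.9-fold lower number from compound 1 to compound 2 (0.28 log units; within the scatter) lies within the scatter. Compound 3 `CCCCCCCCC(=O)N1c2ccccc2CCC1C(=O)Nc1cc(C(F)(F)F)cc(C(F)(F)F)c1` gives 7530 nM, the furthest away from compound 2. Compound 4 `O=C(Nc1ccccc1O)C1CCc2ccccc2N1C(=O)c1ccccc1` differs from compound 2 by hydrogen in place of chloro on an aromatic carbon. Among the measured compounds shown here, no measured step removes a chloro; the one measured step, from compound 1 to compound 2, replaces a whole methyl by a 2-chlorophenyl and stays within the scatter, so a smaller change is expected to stay within it too. Compound 4 is therefore expected to show no step beyond the scatter, a 1.2-fold higher number from compound 2 to compound 4 (0.06 log units; within the scatter), with an estimate of 55000 nM in this assay, ranging from 20000 nM to 150000 nM.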

Compound 4, concentration for 50% growth inhibition: 4210 nM
Compound 4: middle estimate off by 13-fold (1.12 log units), on the high side; the measured number lies below the stated range.
By their numbers in this assay, from the lowest: compounds 4 and 3 (each within the scatter of the next); then compounds 2 and 1 (each within the scatter of the next).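

At this place on the aromatic ring, a single atom counts for a great deal: in this assay, hydrogen in place of chloro gives an 11-fold lower number from compound 2 to compound 4 (1.05 log units; beyond the scatter) and phenyl in place of methyl gives a 21-fold lower number from compound 1 to compound 4 (1.33 log units; beyond the scatter), so the small earlier step to the 2-chlorophenyl group hid a large difference between phenyl and 2-chlorophenyl. Nothing measured here gives a reason for this large step. From the compounds shown here alone, whether a fluoro or a methyl at the same place would behave like chloro or like hydrogen stays open, and so does whether hydrogen gives a similar step on other groups of the shared core.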